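A few compounds are considered here, and "the series" means these few. Any claim that something is new, unique, unknown or untested is made for them only; others in the source may bear on it.

Measured so far in an ADME assay on microsomes from liver (Rattus norvegicus) for metabolic stability, read by LC-MS, using NADPH, at 37 degrees C (a higher number here means that the compound lasts longer, a lower number that the compound disappears faster), as half-life:
- compound 1 `Cc1ccc(C)c(-c2nc(CN3CCC(C(=O)NCCCN4C[C@H](C)C[C@H](C)C4)CC3)c(C)o2)c1` gives 0.5 h
- compound 2 `Cc1oc(-c2ccccc2Cl)nc1CN1CCC(C(=O)NCCCN2C[C@H](C)C[C@H](C)C2)CC1` gives 0.25 h
- compound 3 `Cc1ccccc1-c1nc(CN2CCC(C(=O)NCCCN3CCC(C)(C)CC3)CC2)c(C)o1` gives > 0.5 h as a limit

Compound 3 reads > 0.5 h in this assay and this is a limit of the assay, not a number. What is known of compound 3 is therefore the limit of > 0.5 h in this assay, at which 1 of the 3 values shown sits, and nothing firmer, so any step away from it starts without an exact value.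

Compound 4 `Cc1ccccc1-c1nc(CN2CCC(C(=O)NCCCN3CCCC(CC(C)C)C3)CC2)c(C)o1` gives up the 4,4-dimethylpiperidin-1-yl group, and a group of 10 heavy atoms (9 carbon, 1 nitrogen; one six-membered non-aromatic ring with 1 hetero atom) in place of a group of 8 heavy atoms (7 carbon, 1 nitrogen; one six-membered non-aromatic ring with 1 hetero atom), on a saturated chain carbon, three bonds along the chain from an amide-type nitrogen is the whole change.

The series holds a single measured step between two numbers. That step is a 2.0-fold lower number from compound 1 to compound 2 (0.30 log units; within the scatter) and it lies within the scatter. For the measured compounds named here, it sits on an aromatic carbon and not at the place changed here, so no measured step covers this change directly.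

With a 2.0-fold lower number from compound 1 to compound 2 (0.30 log units; within the scatter) as the only size to go on, no step beyond the scatter is expected in this assay for this change. The estimate amounts to an at least 1.2-fold lower number from compound 3 to compound 4 (0.09 log units; that floor lies within the scatter) as the expected step, which stays within the scatter. In this assay the estimated half-life of compound 4 is 0.4 h with an expected range of 0.2 h to 0.8 h for the measurement.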

Compound 4, half-life: 0.0383 h
Estimate against measurement, compound 4: 10-fold (1.02 log units) above; measured number outside the range, below it.
By their numbers in this assay, from the lowest: compound 4; then compounds 2 and 1 (each within the scatter of the next).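

In this assay, for the compounds shown here, the new step is an at least 13-fold lower number from compound 3 to compound 4 (1.11 log units; beyond the scatter), and it is the first step that lies beyond the scatter. It falls on a saturated chain carbon, three bonds along the chain from an amide-type nitrogen, where 4,4-dimethylpiperidin-1-yl leaves and a group of 10 heavy atoms enters, whereas the only earlier step lay on an aromatic carbon and stayed within the scatter, so this position is the one place shown where a single change has moved the half-life by more than the scatter. The value of compound 3 is a limit of the assay and not a number, so the step has a floor but no exact size: the limit of > 0.5 h in this assay, at which 1 of the 4 values shown sits.

One pair cannot tell whether the fall in half-life follows from the larger group as a whole or from the way its carbons are arranged on the ring, since both differ between compound 3 and compound 4. A plain piperidine, a morpholine or a piperidine carrying a carboxylic acid at this position would show how far the result extends beyond these two groups.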